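A Two-Ring Group Replaces the Thiophene on Compound 1

The source may hold more compounds than are shown below. What is called first, only, known or untested is meant among the compounds shown, and "the series" means these compounds.

Compound 1 `CCN(Cc1ccccc1)C(=O)C1CCN(S(=O)(=O)c2ccc(C)s2)CC1` carries a 5-methylthiophen-2-yl group on its sulfonyl sulfur. In a functional assay on CHO cells for positive allosteric modulation of muscarinic acetylcholine receptor M5 (Homo sapiens), read by calcium flux (a higher number here means a larger maximal response, a lower number a smaller maximal response), compound 1 reaches 64%, the lowest of the two numbers available, with compound 3 as its nearest neighbour. Compound 3 `CCN(Cc1ccccc1)C(=O)C1CCN(S(=O)(=O)c2ccc3[nH]ncc3c2)CC1` gives 86% in this assay. Compound 2 `CCN(Cc1ccccc1)C(=O)C1CCN(S(=O)(=O)c2ccc(C(F)(F)F)nc2)CC1` stands at "not determined" (no result reported) in this assay and contributes no number. For the measured compounds named here, the only measured step that exchanges the group on the sulfonyl sulfur, 1H-indazol-5-yl in place of 5-methylthiophen-2-yl, brought a number 22 percentage points higher from compound 1 to compound 3 (beyond the scatter), a modest rise beyond the scatter.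

Compound 4 `CCN(Cc1ccccc1)C(=O)C1CCN(S(=O)(=O)c2ccc3nsnc3c2)CC1` alters the same position: a group of 9 heavy atoms (6 carbon, 2 nitrogen, 1 sulfur; one five-membered aromatic ring with 3 hetero atoms, one six-membered aromatic ring of carbon only) in place of a group of 6 heavy atoms (5 carbon, 1 sulfur; one five-membered aromatic ring with 1 hetero atom), on a sulfonyl sulfur. As in compound 3, a group with a five-membered aromatic ring and a six-membered aromatic ring of carbon only takes the place of the single five-membered ring, so the step from compound 1 to compound 3 is the one that bears on it. Because that step was a number 22 percentage points higher from compound 1 to compound 3 (beyond the scatter), a rise of similar but somewhat smaller size is expected here, a number 16 percentage points higher from compound 1 to compound 4 (beyond the scatter). Compound 4 is therefore estimated to reach 80% in this assay, within a range from 62% to 98%, with the uncertainty resting on a single comparable step.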

Compound 4, largest response reached (reported as percent of maximum), in percent of the reference or control that the assay uses: 81%
Compound 4: middle estimate off by 1 percentage points, on the low side, and the stated range covers the measured number.
By their numbers in this assay, from the lowest: compound 1; then compounds 4 and 3 (each within the scatter of the next).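

In this assay, the rise is not tied to the 1H-indazol-5-yl group alone: a second group with a five-membered aromatic ring and a six-membered aromatic ring of carbon only, this one with 3 hetero atoms in the five-membered ring and 0 hydrogen-bond donors, gives a number 17 percentage points higher from compound 1 to compound 4 (beyond the scatter) on the same sulfonyl sulfur. The two two-ring groups cannot be told apart, with a number 5 percentage points lower from compound 3 to compound 4 (within the scatter) even though the five-membered ring now holds sulfur as well as nitrogen, so at this position the response tolerates that exchange within the resolution of the measurement. Nothing measured here gives a reason for the rise over the 5-methylthiophen-2-yl group or for the closeness of the two two-ring groups.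

The compounds shown leave open whether the second ring or the ring nitrogens account for the rise, a question that a naphthyl group, with two rings of carbon only, or a plain phenyl group would bear on. They also leave open how far this position accepts a substituent on the two-ring group, such as an amine or a carboxylic acid, and whether the gain holds with the rest of the molecule changed.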